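A few compounds are considered here, and "the series" means these few. Any claim that something is new, unique, unknown or untested is made for them only; others in the source may bear on it.

Compound 1 `CCS(=O)(=O)Nc1ccc2c(c1)C(NC(=S)Nc1cccc(Cl)c1)CC(C)(C)O2` and compound 2 `CCS(=O)(=O)Nc1ccc2c(c1)C(NC(=S)Nc1ccc(Cl)cc1)CC(C)(C)O2` share a core and differ only in the change (4-chlorophenyl in place of 3-chlorophenyl on an amide-type nitrogen), made on an amide-type nitrogen whose other neighbour is a thiocarbonyl carbon. In a functional assay on thoracic aorta (Rattus norvegicus) for inhibition (a lower number here means that less compound is needed, a higher number that more compound is needed for the effect), compound 1 gives 9800 nM, and compound 2 gives 5100 nM; the step of a 1.9-fold lower number from compound 1 to compound 2 (0.28 log units; within the scatter) is small. Compound 3 `CCS(=O)(=O)Nc1ccc2c(c1)C(NC(=O)Nc1cccc(Cl)c1)CC(C)(C)O2` carries a carbonyl carbon next to that nitrogen instead; how its core differs from the core of compound 1 is not broken down here. In this assay compound 3 gives 17200 nM. Compound 4 `CCS(=O)(=O)Nc1ccc2c(c1)C(NC(=O)Nc1ccc(Cl)cc1)CC(C)(C)O2` is made from compound 3 by 4-chlorophenyl in place of 3-chlorophenyl on an amide-type nitrogen, the same kind of change as before, here on a nitrogen whose other neighbour is a carbonyl carbon. Going by the values given here, the step of a 1.9-fold lower number from compound 3 to compound 4 (0.28 log units; within the scatter) is expected to be small, like the measured one, because the only guide is a 1.9-fold lower number from compound 1 to compound 2 (0.28 log units; within the scatter). Compound 4 is therefore estimated at 9000 nM in this assay.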

Compound 4, half-maximal effective concentration: > 10000 nM
Compound 4: no number, only a limit; the forecaster's own chance of this, stated with the estimate: 10%; middle value at least 1.1-fold (0.04 log units) from the limit.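

In this assay compound 4 gives > 10000 nM, which is a limit and not a number. The step from compound 3 to compound 4 therefore cannot be read. As far as these compounds go, whether 4-chlorophenyl in place of 3-chlorophenyl has the same effect on carbonyl and thiocarbonyl compounds stays open.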